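The compounds below may be only part of what the source reports. "The series", "measured", "known", "first", "only" and "open" are said of these compounds alone.

Measured in a functional assay on Cortical neurone cells (Rattus norvegicus, strain Sprague-Dawley), read by MTT assay, with stated times of 24 h and 2 h, tested at 0.1 uM; a higher number here means a stronger effect of the compound at the concentration tested, a lower number a weaker effect:
compound 1 `COC(=O)C1=CN(C(C)C)C(=O)[C@@H]2C(CN3CCN(Cc4ccc([N+](=O)[O-])cc4)CC3)=CC[C@H]12`: 67.1%
compound 2 `COC(=O)C1=CN(C(C)C)C(=O)[C@@H]2C(CN3CCN(Cc4ccc(C(F)(F)F)cc4)CC3)=CC[C@H]12`: 59.1%
compound 3 `COC(=O)C1=CN(C(C)C)C(=O)[C@@H]2C(CN3CCN(Cc4cccc(C(F)(F)F)c4)CC3)=CC[C@H]12`: 58.7%

Compound 3 holds the lowest of the three numbers, but the steps of a number 0.4 percentage points lower from compound 2 to compound 3 (within the scatter) and a number 8.4 percentage points lower from compound 1 to compound 3 (within the scatter) both sit within the scatter, so no order among the three can be read. Compound 4 `COC(=O)C1=CN(C(C)C)C(=O)[C@@H]2C(CN3CCN(Cc4cccc(OC)c4)CC3)=CC[C@H]12` is made from compound 3 by methoxy in place of trifluoromethyl on an aromatic carbon. The only measured substitution on this aromatic ring, a number 8 percentage points lower from compound 1 to compound 2 (within the scatter), also stayed within the scatter. Going by the values given here, no measured step brings in a methoxy, so the change itself is uncalibrated. The working prior is therefore no step beyond the scatter in this assay, with wide uncertainty. For compound 4 the expected step is a number 0.7 percentage points lower from compound 3 to compound 4 (within the scatter). Compound 4 is estimated at 58%, range 44% to 70%.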

Compound 4, a percentage reported as activity, at one concentration (the size of the read-out at that concentration, not a potency): 60.6%
Estimate against measurement, compound 4: 2.6 percentage points below; the measured number falls inside the stated range.
By their numbers in this assay, from the lowest: compounds 3, 2, 4 and 1 (each within the scatter of the next).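

Methoxy in place of trifluoromethyl on this aromatic carbon, which brings in a hydrogen-bond acceptor, gives a number 1.9 percentage points higher from compound 3 to compound 4 (within the scatter) in this assay. The steps from the other two compounds, a number 1.5 percentage points higher from compound 2 to compound 4 (within the scatter) and a number 6.5 percentage points lower from compound 1 to compound 4 (within the scatter), also stay within the scatter, so the four compounds remain unordered at this concentration. No evidence accompanies these numbers to explain them.

As far as these compounds go, whether an amine or a carboxylic acid on this aromatic ring would give a step beyond the scatter stays open. From the compounds shown here alone, the read-out shows the size of the effect at a single concentration, and whether the effect would be stronger or weaker at other concentrations also stays open.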